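The compounds below may be only part of what the source reports. "The series", "measured", "known", "first", "only" and "open" are said of these compounds alone.

In a physicochemical assay for lipophilicity, read by HPLC, at pH 7.5 (a higher number here means a more lipophilic compound, a lower number a more polar compound), compound 1 (`CCOc1ccccc1-c1ccc(-c2nc3cnccc3c(C[C@H](C)C(N)=O)c2C#N)cc1`) gives 3 and stands highest of the two measured compounds. Compound 2 (`CC[C@@H](Nc1c(C#N)c(-c2ccc(-c3cccnc3C)cc2)nc2cnccc12)C(N)=O`) gives 1.9 as the lower number, a gap beyond the scatter. Compound 3 (`CCOc1ccccc1-c1ccc(-c2nc3cnccc3c(N[C@H](CC(C)C)C(N)=O)c2C#N)cc1`) has (1-carbamoyl-3-methylbutyl)amino in place of 2-carbamoylpropyl on an aromatic carbon of the core of compound 1 ((1-carbamoyl-3-methylbutyl)amino in place of 2-carbamoylpropyl on an aromatic carbon). Within the data shown here, no measured pair isolates this change. A small upward step is expected, estimated as a number 0.40 log units higher from compound 1 to compound 3 (beyond the scatter) and close to the scatter. The expected value for compound 3 is 3.4 with an estimated range from 2.8 to 3.9 in this series.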

Compound 3, distribution coefficient: 3.4
Beside the measured number, compound 3's estimate shows no gap at the digits printed, within the range that was stated.
By their numbers in this assay, from the lowest: compound 2; then compound 1; then compound 3.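

Among these compounds, at this position on the shared core, opposite the ring nitrogen, (1-carbamoyl-3-methylbutyl)amino in place of 2-carbamoylpropyl moves this assay by a number 0.40 log units higher from compound 1 to compound 3 (beyond the scatter) and gives the first single-place step. The step is modest and upward, although the entering group has more heavy atoms, hydrogen-bond donors and hydrogen-bond acceptors. No measurement here accounts for the step. The nitrogen link and the longer branched chain enter together, and their shares in the step remain unresolved. Going by these compounds, how a carboxylic acid in place of the carbamoyl group would read in this assay also remains open.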